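Removing a Methyl from Three Inactive Amides

The source may hold more compounds than are shown below. What is called first, only, known or untested is meant among the compounds shown, and "the series" means these compounds.

Three related amides have been tested in an assay on isolated protein for inhibition of thyroid hormone receptor alpha (Homo sapiens), read by fluorescence polarization; on this read-out higher numbers stand for weaker inhibition and lower numbers for stronger inhibition. Compound 1, `CS(=O)(=O)c1ccc(C(=O)N2CCC(C(=O)N3CCN(c4ccc(F)cc4)CC3)CC2)cc1[N+](=O)[O-]`, carries a piperidine amide linked to a fluorophenyl piperazine. In this assay compound 1 gives > 60000 nM, which is a limit of the assay rather than a number. Compound 2, `CN(Cc1cccc(F)c1)C(=O)CN(C)C(=O)c1ccc(S(C)(=O)=O)c([N+](=O)[O-])c1`, replaces that arrangement with a glycinamide chain ending in a fluorobenzyl group. In this assay compound 2 gives > 60000 nM, again a limit and not a measured number. Compound 3, `CC1CCN(C(=O)CCCNC(=O)c2ccc(S(C)(=O)=O)c([N+](=O)[O-])c2)CC1`, joins the shared core through a short chain to a 4-methylpiperidin-1-yl amide. In this assay compound 3 gives > 60000 nM, which is likewise a limit. All three measured compounds therefore share (the limit of > 60000 nM in this assay, at which 3 of the 3 values shown sit), so no ranking among them is possible.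

Compound 4, `CS(=O)(=O)c1ccc(C(=O)NCCCC(=O)N2CCCCC2)cc1[N+](=O)[O-]`, differs from compound 3 in one place: hydrogen in place of methyl on a saturated ring carbon. No comparable single change between measured compounds exists here, so nothing measured says what such a change does. Since compound 3 sits at the limit, removing one methyl is expected to leave compound 4 at the limit as well, and the step that the limit leaves unreadable from compound 3 to compound 4 is estimated to be none beyond the scatter. Compound 4 is expected to give 100000 nM, somewhere between 40000 nM and 300000 nM.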

Compound 4, half-maximal inhibitory concentration: > 60000 nM
Compound 4: only a limit was reported (the forecaster's own chance of this, stated with the estimate: 90%); the middle value does not contradict the limit.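

Compound 3 and compound 4 each return a limit and not a number, so no step can be read for hydrogen in place of methyl, and the same holds across the whole set: the limit of > 60000 nM in this assay, at which 4 of the 4 values shown sit.

The compounds shown leave open whether any of these amides would give a measurable value, and whether going from 4-methylpiperidin-1-yl to piperidin-1-yl changes inhibition at all.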